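Purine Glycinamide Amino Acid Conjugates in an Oral Tail Flick Test

A few compounds are considered here, and "the series" means these few. Any claim that something is new, unique, unknown or untested is made for them only; others in the source may bear on it.

Three compounds built on a shared core were examined in a functional assay on the whole organism (Tail, strain ICR) with Mus musculus as the target, in the tail flick test, with a stated time of 150 min, at a dose of 25 umol/kg by the oral route; on this read-out higher numbers stand for a stronger effect at the one dose given and lower numbers for a weaker effect. Compound 3 `CC(C)C[C@H](NC(=O)CN(c1nc(Cl)nc2[nH]cnc12)C1CC1)C(=O)O` gives 9.13%, and compound 1 `NC(=O)C[C@H](NC(=O)CN(c1nc(Cl)nc2[nH]cnc12)C1CC1)C(=O)O` gives 7.51%. The difference between them is carbamoyl in place of isopropyl on a saturated chain carbon, two bonds along the chain from an amide-type nitrogen and a carbonyl carbon, and the resulting step was a number 1.6 percentage points lower from compound 3 to compound 1 (within the scatter). Compound 2 `CC(C)C[C@H](NC(=O)CN(c1nc(Cl)nc2[nH]cnc12)C1CC1)C(=O)OCc1ccccc1` differs from compound 3 by benzyl in place of hydrogen on an oxygen next to a carbonyl group. Compound 2 gives 5.26%; the step was a number 3.9 percentage points higher from compound 2 to compound 3 (within the scatter). Compound 4 `NC(=O)C[C@H](NC(=O)CN(c1nc(Cl)nc2[nH]cnc12)C1CC1)C(=O)OCc1ccccc1` is not yet measured. It differs from compound 2 by carbamoyl in place of isopropyl on a saturated chain carbon, two bonds along the chain from an amide-type nitrogen and a carbonyl carbon, the same change that separates compound 3 from compound 1, and that step lay within the scatter. The step from compound 2 to compound 4 is therefore expected to be a number 1.3 percentage points lower from compound 2 to compound 4 (within the scatter), because the same change gave a number 1.6 percentage points lower from compound 3 to compound 1 (within the scatter). On that basis compound 4 is estimated to give 4% in this assay, with a likely span from 0% to 12%.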

Compound 4, a percentage reported as activity, at one dose (the size of the read-out at that dose, not a potency): 13.5%
Beside the measured number, compound 4's estimate is 9.5 percentage points below it; the whole stated range lies below it.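

In this assay, carbamoyl in place of isopropyl gave a number 8.2 percentage points higher from compound 2 to compound 4 (within the scatter), and this step does not differ beyond the scatter from the one seen on the other core: the same change on two cores in this assay, a number 1.6 percentage points lower (within the scatter) from compound 3 to compound 1 and a number 8.2 percentage points higher (within the scatter) from compound 2 to compound 4, 9.9 percentage points apart, within the scatter of two such steps
Benzyl in place of hydrogen on the oxygen gave a number 6 percentage points higher from compound 1 to compound 4 (within the scatter), and the same holds for this change: the same change on two cores in this assay, a number 3.9 percentage points higher (within the scatter) from compound 2 to compound 3 and a number 6 percentage points lower (within the scatter) from compound 4 to compound 1, 9.9 percentage points apart, within the scatter of two such steps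
This shows no dependence of either change on the core, but it does not show that either change carries over with a fixed size or has any effect of its own, since every step here lies within the scatter.

The compounds shown leave open whether an amine, a carboxylic acid or a longer chain in place of the isobutyl or carbamoylmethyl side chain would move the read-out beyond the scatter. On these data alone, whether a methyl ester would behave like the benzyl ester also remains open.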